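The source may report more compounds than this note shows. Statements on the series, on what has been measured and on what is new or still open speak of the compounds shown alone.

Compound 1 `NC(=O)N1CCN(C(=S)SCc2cn(Cc3ccc(Cl)cc3)nn2)CC1` and compound 2 `CCNC(=O)N1CCN(C(=S)SCc2cn(Cc3ccc(Cl)cc3)nn2)CC1` share one core carrying a 4-chlorobenzyl group, and differ only by an ethyl in place of hydrogen on an amide-type nitrogen. In a functional assay on MCF7 cells (Homo sapiens) for cytotoxicity, read by MTT assay, with a stated time of 72 h (on this read-out higher numbers stand for weaker inhibition and lower numbers for stronger inhibition), compound 1 gives no number but only a limit, > 128000 nM. In this assay compound 2 likewise gives only a limit, > 128000 nM. The step that the two limits leave unreadable from compound 1 to compound 2 is thus not readable, as both values sit at the limit of > 128000 nM in this assay, at which 2 of the 2 values shown sit. Compound 3 `CCNC(=O)N1CCN(C(=S)SCc2cn(Cc3ccc(OC)cc3)nn2)CC1` differs from compound 2 by methoxy in place of chloro on an aromatic carbon. For the measured compounds named here, no measured step bears on this change, and the one step recorded has no readable size to lean on. The expected step is therefore a step that the limit leaves unreadable from compound 2 to compound 3, none that can be separated from the scatter, with a limit again the likeliest outcome. In this assay compound 3 is estimated at 150000 nM, within 40000 nM to 500000 nM.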

Compound 3, half-maximal inhibitory concentration: 97600 nM
Compound 3: middle estimate off by 1.5-fold (0.19 log units), on the high side; the measured number falls inside the stated range.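

Compound 3 is the first compound shown to give a number rather than a limit in this assay, so this aromatic carbon, para to a large group, is a place where a change can register on this read-out. The change from 4-chlorobenzyl to 4-methoxybenzyl gives only a floor, an at least 1.3-fold lower number from compound 2 to compound 3 (0.11 log units; that floor lies within the scatter), and compound 2 itself gives only a limit, > 128000 nM. The rest of the series offers no further number to set beside compound 3: the limit of > 128000 nM in this assay, at which 2 of the 3 values shown sit.

As far as these compounds go, the true size of the step stays open, as does whether methoxy would give a number when carried on compound 1, with its unsubstituted amide nitrogen. Also open, from the compounds shown here alone, is how an amine, a carboxylic acid or a longer alkoxy chain at this position would read.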